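The source may report more compounds than this note shows. Statements on the series, on what has been measured and on what is new or still open speak of the compounds shown alone.

For the measured compounds named here, compound 1 `CC(C)c1nn(-c2ccc(C(N)=O)c(N[C@H]3CC[C@H](O)CC3)c2)c2nccc(-n3cnc(-c4cncnc4)c3)c12` gives 387 nM in a functional assay on SK-BR-3 cells (Homo sapiens) for inhibition, read by CellTiter-Glo, with a stated time of 72 h (on this read-out higher numbers stand for weaker inhibition and lower numbers for stronger inhibition), the lowest of the two numbers so far, though compound 2 `CC(C)c1nn(-c2ccc(C(N)=O)c(N[C@H]3CC[C@H](O)CC3)c2)c2cncc(-c3cnc4ccccc4c3)c12` at 473 nM in this assay lies within the scatter of it. Compound 3 `CC(C)c1nn(-c2ccc(C(N)=O)c(N[C@H]3CC[C@H](O)CC3)c2)c2nccc(-c3cccnc3)c12` is not yet measured; it differs from compound 1 by pyridin-3-yl in place of 4-(pyrimidin-5-yl)-1H-imidazol-1-yl on an aromatic carbon. Going by the values given here, no measured pair shows this change, so the step is unanchored. The smaller entering group is expected to cost some potency, a step from compound 1 to compound 3 of roughly a 2.3-fold higher number from compound 1 to compound 3 (0.37 log units; beyond the scatter) in this assay. Compound 3 is therefore expected at about 900 nM in this assay, within 300 nM to 3000 nM.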

Compound 3, half-maximal inhibitory concentration: 464 nM
Compound 3: the middle estimate sits 1.9-fold (0.29 log units) above what was measured; the range from low to high includes it.
By their numbers in this assay, from the lowest: compounds 1, 3 and 2 (each within the scatter of the next).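

At this aromatic carbon, opposite the ring nitrogen, pyridin-3-yl in place of 4-(pyrimidin-5-yl)-1H-imidazol-1-yl gives a 1.2-fold higher number from compound 1 to compound 3 (0.08 log units; within the scatter) in this assay. The position therefore carries either of these two aromatic groups, with one ring or two, without a readable loss, so the second ring of the leaving group adds nothing that this read-out can resolve. No measurement on hand bears on why. Open, going by these compounds, is whether a non-aromatic group here, such as morpholine or a primary amine, holds this level, and whether plain hydrogen at this carbon does.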